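The compounds below may be only part of what the source reports. "The series", "measured", "known", "first", "only" and "open" are said of these compounds alone.

The measured compounds and their values in a functional assay on Ehrlich cells (Mus musculus) for cytotoxicity, read by trypan blue exclusion, with a stated time of 2 h, tested at 25 ug/mL; a higher number here means a stronger effect of the compound at the concentration tested, a lower number a weaker effect:

compound 1 `N#CC1=C(NC(=S)Nc2ccc(Cl)cc2)N(c2ccc(S(N)(=O)=O)cc2)C2=C(C(=O)CCC2)C1c1ccc(Cl)cc1Cl`: 60%
compound 2 `N#CC1=C(NC(N)=O)N(c2ccc(S(N)(=O)=O)cc2)C2=C(C(=O)CCC2)C1c1ccc(Cl)cc1Cl`: 35%

For the measured compounds named here, compound 2 stands lowest of the two numbers in this assay; its nearest neighbour is compound 1, and the one measured step, a number 25 percentage points lower from compound 1 to compound 2 (beyond the scatter), goes with the exchange of the aryl-bearing thiourea for the smaller ureido group on the amine nitrogen, a change beyond the scatter but only modest in size.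

Compound 3 `N#CC1=C(NC(=O)CCC(=O)O)N(c2ccc(S(N)(=O)=O)cc2)C2=C(C(=O)CCC2)C1c1ccc(Cl)cc1Cl` is not yet measured. It differs from compound 2 at the carbonyl carbon: 2-carboxyethyl in place of amino on a carbonyl carbon. This is the same region of the shared core that the measured step touched, yet the measured step exchanged an aromatic-ring-bearing group for a small one, whereas the present change lengthens the group without adding a ring. Going by the values given here, no measured pair tests that kind of change, so the one step gives only a loose guide. On that basis compound 3 is expected to stay close to compound 2 in this assay, with any step a number 5 percentage points higher from compound 2 to compound 3 (within the scatter) likely within or near the scatter. The estimate for compound 3 is 40%, within the range 25% to 55%.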

Compound 3, a percentage reported as activity, at one concentration (the size of the read-out at that concentration, not a potency): 35%
The estimate for compound 3 lay 5 percentage points above the measured number, within the range that was stated.
By their numbers in this assay, from the lowest: compounds 2 and 3 (each within the scatter of the next); then compound 1.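

In this assay, the exchange of amino for 2-carboxyethyl on the carbonyl carbon gives no change at the digits printed from compound 2 to compound 3 (within the scatter), so this position tolerates a longer, ring-free chain ending in a carboxylic acid without a step beyond the scatter. The earlier compounds had shown only the loss of the ring-bearing thiourea group, and the further comparison gives a number 25 percentage points lower from compound 1 to compound 3 (beyond the scatter), matching in size the earlier a number 25 percentage points lower from compound 1 to compound 2 (beyond the scatter). Among these three compounds, the two ring-free groups on the amine nitrogen therefore both stand lower than the ring-bearing group of compound 1, and neither goes against that pattern, though nothing measured here bears on the reason for it.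

Because compound 1 differs from the others in both its aromatic ring and its thiocarbonyl sulfur, these compounds cannot separate the two: a plain thiourea and a urea carrying the same chlorinated phenyl ring would each speak to that question. Going by these compounds, it also remains open whether the end of the 2-carboxyethyl chain matters at all, which a methyl ester or a primary amine at that end could test.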